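Replacing the furan-3-yl group of compound 2

The source may hold more compounds than are shown below. What is called first, only, known or untested is meant among the compounds shown, and "the series" means these compounds.

Within the data shown here, in a functional assay on MCF7 cells (Homo sapiens) for inhibition, read by sulforhodamine B assay (on this read-out higher numbers stand for lower toxicity in this test and lower numbers for higher toxicity in this test), compound 2 `CC1=CC(=O)[C@H]2C(C)(C)CCC[C@]2(C)[C@H]1/C=C/c1ccoc1` gives 19800 nM, the only value that is an actual number. Compound 3 `CC1=CC(=O)[C@H]2C(C)(C)CCC[C@]2(C)[C@H]1/C=C/C1=CCOC1=O` shares the core of compound 2 and differs in one place: a group of 6 heavy atoms (4 carbon, 2 oxygen; one five-membered non-aromatic ring with 1 hetero atom) in place of a group of 5 heavy atoms (4 carbon, 1 oxygen; one five-membered aromatic ring with 1 hetero atom), on a double-bonded chain carbon bound to a double-bonded chain carbon. Compound 1 `CC1(C)CCC[C@]2(C)[C@@H](/C=C/C3=CCOC3=O)C(C=O)=CC(=O)[C@@H]12` also carries the entering group, and its value, > 100000 nM, is a limit of the assay, so a shift towards lower toxicity is expected. The expected size of the change, modestly beyond the usual scatter, is a 2.3-fold higher number from compound 2 to compound 3 (0.36 log units; beyond the scatter). For compound 3 the estimated value is 45000 nM, with an expected range of 18000 nM to 100000 nM.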

Compound 3, concentration lethal to 50% of the cells: 19800 nM
Beside the measured number, compound 3's estimate is 2.3-fold (0.36 log units) above it; the measured number falls inside the stated range.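

In this assay, the step at the double-bonded chain carbon is no change at the digits printed from compound 2 to compound 3 (within the scatter), so furan-3-yl and the entering five-membered non-aromatic ring read alike on the methyl-bearing core. Among these compounds, with that ring held, methyl in place of formyl on a double-bonded ring carbon gives an at least 5.0-fold lower number from compound 1 to compound 3 (0.70 log units; beyond the scatter), the only step here beyond the scatter. Compound 1 stands at a limit of the assay: the limit of > 100000 nM in this assay, at which 1 of the 3 values shown sits.

As far as these compounds go, the full size of the formyl-to-methyl step remains open. So does how an amine, a carboxylic acid or a longer chain would read at the double-bonded chain carbon.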